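Aryl-chain citrate analogues: moving from compound 3 to compound 4

The source may report more compounds than this note shows. Statements on the series, on what has been measured and on what is new or still open speak of the compounds shown alone.

Compound 1 `O=C(O)CC(O)(CSCCCc1ccc(Cl)cc1Cl)C(=O)O` gives 390000 nM in an assay on isolated protein for inhibition of ATP-citrate synthase (Rattus norvegicus); on this read-out higher numbers stand for weaker inhibition and lower numbers for stronger inhibition.
Compound 2 `COc1ccc(CCCCCCSCC(O)(CC(=O)O)C(=O)O)cc1` gives 280000 nM in this assay.
Compound 3 `Cc1ccc(CCCCCCSCC(O)(CC(=O)O)C(=O)O)c(C)c1` gives 160000 nM in this assay.

Among these three numbers compound 3 stands lowest. Its nearest neighbour is compound 2, and the step of a 1.8-fold lower number from compound 2 to compound 3 (0.24 log units; within the scatter) falls within the scatter; compound 1, with 390000 nM, lies further off, beyond the scatter. Compound 4 `O=C(O)CC(O)(CSCCCCCCc1ccc(F)cc1F)C(=O)O` differs from compound 3 by 2,4-difluorophenyl in place of 2,4-dimethylphenyl on a saturated chain carbon, six bonds along the chain from a sulfur. Among the measured compounds shown here, no measured step exchanges aryl substituents in exactly this way; the only step that bears on it, a 1.8-fold lower number from compound 2 to compound 3 (0.24 log units; within the scatter), shows one aryl group replacing another moved the number little. Therefore only a small step is expected, a 1.6-fold higher number from compound 3 to compound 4 (0.19 log units; within the scatter) in this assay, not beyond the scatter. Compound 4 is estimated at 250000 nM, with a range of 100000 nM to 600000 nM.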

Compound 4, inhibition constant: 270000 nM
Beside the measured number, compound 4's estimate is 1.1-fold (0.03 log units) below it; the measured number falls inside the stated range.
By their numbers in this assay, from the lowest: compounds 3, 4, 2 and 1 (each within the scatter of the next, the first and the last beyond it).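

In this assay the change to 2,4-difluorophenyl from 2,4-dimethylphenyl gives a 1.7-fold higher number from compound 3 to compound 4 (0.23 log units; within the scatter) and the change from 4-methoxyphenyl gives a 1.0-fold lower number from compound 2 to compound 4 (0.02 log units; within the scatter) at this place on a saturated chain carbon, six bonds along the chain from a sulfur. The three aryl groups therefore stand within the scatter of one another, so fluorine on the ring separates compound 4 from neither compound 2 nor compound 3. Nothing available explains this result. On these data alone, whether an aryl group bearing an amine or a carboxylic acid would behave the same at this place remains open, as does the effect of a longer chain with 2,4-difluorophenyl kept in place.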